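A few compounds are considered here, and "the series" means these few. Any claim that something is new, unique, unknown or untested is made for them only; others in the source may bear on it.

Compound 1 `CCCCCc1cccc(NC(=O)NC(=O)CCl)c1`: 8300 nM
Compound 2 `CCNC(=O)NCc1ccc(C(C)(C)C)cc1`: > 100000 nM

In a functional assay on MCF7 cells (Homo sapiens) for antiproliferative activity, with a stated time of 48 h (on this read-out lower numbers stand for stronger inhibition and higher numbers for weaker inhibition), compound 1 gives 8300 nM. For compound 2 the read-out is only a limit of the assay, > 100000 nM, so compound 2 sits at the limit of > 100000 nM in this assay, at which 1 of the 2 values shown sits, and no number of its own is known. Compound 3 `CC(C)(C)c1ccc(CNC(=O)CCCCl)cc1` differs from compound 2 by 3-chloropropyl in place of ethylamino on a carbonyl carbon. Within the data shown here, no measured pair shows this change, so the step from compound 2 to compound 3 is expected to be an at least 2.0-fold lower number from compound 2 to compound 3 (0.30 log units; that floor lies within the scatter), towards stronger inhibition but with wide uncertainty. Compound 3 is therefore estimated at 50000 nM, within 10000 nM to 200000 nM.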

Compound 3, half-maximal inhibitory concentration: 92000 nM
Compound 3: middle estimate off by 1.8-fold (0.26 log units), on the low side; the measured number falls inside the stated range.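

In this assay, 3-chloropropyl in place of ethylamino on a carbonyl carbon gives an at least 1.0-fold lower number from compound 2 to compound 3 (0.03 log units; that floor lies within the scatter). Compound 3 thus gives this position its first number of its own. As far as these compounds go, compound 2 stands at a limit of the assay, so the step has only a floor and its true size stays open: the limit of > 100000 nM in this assay, at which 1 of the 3 values shown sits.

Still open, from the compounds shown here alone, is whether a shorter chain, a longer chain or an amine on this carbonyl carbon would shift the read-out. Compound 1 differs from compound 3 in more than one place, so it cannot settle this.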